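A few compounds are considered here, and "the series" means these few. Any claim that something is new, unique, unknown or untested is made for them only; others in the source may bear on it.

In a functional assay on SGC-7901 cells (Homo sapiens) for antiproliferative activity, read by MTT assay, with a stated time of 48 h (a lower number here means a stronger inhibitor, a higher number a weaker inhibitor), three compounds have been measured so far

Compound 1 `COc1ccccc1-c1nnc(SCc2ccc(Cl)nc2)o1` gives 8.2 ug/mL
Compound 2 `COc1ccc(-c2nnc(SCc3ccc(Cl)nc3)o2)cc1` gives 3.5 ug/mL
Compound 3 `CCOc1ccccc1-c1nnc(SCc2ccc(Cl)nc2)o1` gives 10.3 ug/mL

Compound 2 stands lowest of the three, with its gaps to both others beyond the scatter. Compound 4 `Fc1ccc(-c2nnc(SCc3ccc(Cl)nc3)o2)cc1`, not yet measured, departs from it by fluoro in place of methoxy on an aromatic carbon on the ring that carries the methoxy. For the measured compounds named here, the one measured step, a 1.3-fold higher number from compound 1 to compound 3 (0.10 log units; within the scatter), lies within the scatter, but it puts methyl in place of hydrogen on a chain carbon and does not replace methoxy with fluoro, so no measured step bears directly on this change. Compound 2 at 3.5 ug/mL sits at the low end of the three, so in this assay a small rise is expected rather than a further drop. The expected change is a 1.3-fold higher number from compound 2 to compound 4 (0.11 log units; within the scatter) in this estimate. For compound 4 the estimated value is 4.5 ug/mL with an expected range from 1.8 ug/mL to 11 ug/mL.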

Compound 4, half-maximal inhibitory concentration: 3.67 ug/mL
Compound 4: the middle estimate sits 1.2-fold (0.09 log units) above what was measured; the measured number falls inside the stated range.
By their numbers in this assay, from the lowest: compounds 2 and 4 (each within the scatter of the next); then compounds 1 and 3 (each within the scatter of the next).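

In this assay, on this aromatic carbon para to a large group, fluoro takes the place of methoxy with a 1.0-fold higher number from compound 2 to compound 4 (0.02 log units; within the scatter), so the two groups cannot be told apart here. The earlier compounds shown here all carried an oxygen-linked group on this ring, and this pair shows that the number holds without that oxygen and without the methyl attached to it. Nothing measured here offers an explanation for this result.

On these data alone, whether an amine, a carboxylic acid or a longer chain on this same carbon would keep the number remains open.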